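The compounds below may be only part of what the source reports. "The series", "measured", "known", "first", "only" and "open" are said of these compounds alone.

Measured so far:
compound 1 `Cc1cc(O)c(C(C)C)cc1-c1cc(-c2ccccc2)c(C#N)c(=O)[nH]1` — 29%
compound 2 `COc1cc(-c2cc(-c3cc(C(C)C)c(O)cc3C)[nH]c(=O)c2C#N)cc(OC)c1OC` — 55%

In a functional assay for inhibition, tested at 40 ug/mL (on this read-out higher numbers stand for a stronger effect at the one concentration tested and lower numbers for a weaker effect), compound 2 holds the higher of the two numbers; compound 1 sits lower by a margin beyond the usual scatter. Among the measured compounds shown here, the two structures differ in more than one place, so no single step connects them, and their values are taken only as they stand.

Compound 3 `COc1ccc(-c2cc(-c3cc(C(C)C)c(O)cc3C)[nH]c(=O)c2C#N)cc1OC` differs from compound 2 by hydrogen in place of methoxy on an aromatic carbon. For the measured compounds named here, no measured step of this kind exists. The expected step of a number 10 percentage points lower from compound 2 to compound 3 (within the scatter) is a small loss, likely within the scatter. Compound 3 is expected to give 45%, within 25% to 65%.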

Compound 3, a percentage reported as inhibition, at one concentration (the size of the read-out at that concentration, not a potency): 44%
Compound 3: the middle estimate sits 1 percentage points above what was measured, within the range that was stated.
By their numbers in this assay, from the lowest: compound 1; then compound 3; then compound 2.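

Among the compounds shown here, the step of a number 11 percentage points lower from compound 2 to compound 3 (beyond the scatter) in this assay gives the first one-place reading at this aromatic carbon, and the methoxy there counts for a modest amount. The step of a number 15 percentage points higher from compound 1 to compound 3 (beyond the scatter) adds that 3,4-dimethoxyphenyl in place of phenyl also moves the number modestly, so in both steps the compound carrying more methoxy holds the higher number. For the compounds shown here, nothing measured so far speaks to why these steps arise.

Still open, going by these compounds, is whether an amine or a longer alkoxy chain on this carbon would keep, raise or lower the number.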